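Swapping a Fluorophenyl for a Chlorothiophene: Expected Potency

A few compounds are considered here, and "the series" means these few. Any claim that something is new, unique, unknown or untested is made for them only; others in the source may bear on it.

Compound 1 `CCOC(=O)c1cnc(CC)nc1NN1C(=O)C=C(C)C1=O`: 10000 nM
Compound 2 `CCOC(=O)c1cnc(-c2cnc3ccccc3c2)nc1NN1C(=O)C=C(C)C1=O`: 6000 nM
Compound 3 `CCOC(=O)c1cnc(-c2ccc(F)cc2)nc1NN1C(=O)C=C(C)C1=O`: 700 nM

These three compounds were tested in a functional assay on Jurkat cells for inhibition of nuclear factor NF-kappa-B complex (Homo sapiens); a lower number here means a stronger inhibitor, a higher number a weaker inhibitor. Compound 3 gives the lowest number and is the strongest inhibitor of the three: a 14-fold lower number from compound 1 to compound 3 (1.15 log units; beyond the scatter) and an 8.6-fold lower number from compound 2 to compound 3 (0.93 log units; beyond the scatter), both beyond the scatter, whereas a 1.7-fold lower number from compound 1 to compound 2 (0.22 log units; within the scatter). Compound 4 `CCOC(=O)c1cnc(-c2ccc(Cl)s2)nc1NN1C(=O)C=C(C)C1=O` has not been measured. It differs from compound 3 in one place: 5-chlorothiophen-2-yl in place of 4-fluorophenyl on an aromatic carbon. The measured steps show that an aromatic ring in place of ethyl lowers the number, and that the choice of ring matters, since quinolin-3-yl in compound 2 falls well short of 4-fluorophenyl in compound 3. Since 5-chlorothiophen-2-yl is again an aromatic ring, only a small step is expected, a 1.3-fold higher number from compound 3 to compound 4 (0.11 log units; within the scatter). Compound 4 is therefore expected to give about 900 nM in this assay, within a range of 250 nM to 3500 nM.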

Compound 4, half-maximal inhibitory concentration: 300 nM
For compound 4 the middle estimate is 3.0-fold (0.48 log units) above the measured one; low and high end bracket the measured number.
By their numbers in this assay, from the lowest: compound 4; then compound 3; then compounds 2 and 1 (each within the scatter of the next).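

Replacing the six-membered carbon ring with a five-membered aromatic ring holding one hetero atom does not cost potency at this position between two ring nitrogen atoms: there is a 2.3-fold lower number from compound 3 to compound 4 (0.37 log units; beyond the scatter). The 5-chlorothiophen-2-yl group also far outdoes the other two groups, with a 20-fold lower number from compound 2 to compound 4 (1.30 log units; beyond the scatter) and a 33-fold lower number from compound 1 to compound 4 (1.52 log units; beyond the scatter), which makes compound 4 the strongest inhibitor of the four. Nothing available explains this gain.

On these data alone, it remains open whether the gain follows the chlorine or the thiophene ring, which 4-chlorophenyl or plain thiophen-2-yl would separate. As far as these compounds go, how an amine or a carboxylic acid on the ring would fare is also open.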